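The source may report more compounds than this note shows. Statements on the series, on what has been measured and on what is new or still open speak of the compounds shown alone.

Measured so far:
- compound 1, `CCCCCCCCCCc1ccc(-c2noc(CCCN)n2)cc1`, 67%
- compound 2, `CCCCCCCCCCc1ccc(-c2noc(CC[C@@H](N)C(=O)O)n2)cc1`, 5%
- compound 3, `CCCCCCCCCCc1ccc(-c2noc([C@H](N)CCCCN)n2)cc1`, 50%

All three share one core and were tested in an assay on HeLa cells for inhibition of sphingosine-1-phosphate transporter SPNS2 (Mus musculus), read by LC-MS, tested at 2 uM; on this read-out higher numbers stand for more inhibition at the one concentration tested (going by the name of the read-out) and lower numbers for less inhibition. Compound 3 stands second of the three: compound 1 lies above it, as shown by a number 17 percentage points lower from compound 1 to compound 3 (beyond the scatter), and compound 2 lies well below it, as shown by a number 45 percentage points higher from compound 2 to compound 3 (beyond the scatter).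

Compound 4, `CCCCCCCCCCc1ccc(-c2noc([C@H](CCCCN)NC(C)=O)n2)cc1`, is not yet measured. It differs from compound 3 at one place: 1-acetamido-5-aminopentyl in place of 1,5-diaminopentyl on an aromatic carbon.

Among the measured compounds shown here, two measured steps bear on this change, both altering the same chain carbon of the side chain. The step of a number 62 percentage points lower from compound 1 to compound 2 (beyond the scatter) shows that placing a carboxy on that carbon cost a great deal, while a number 17 percentage points lower from compound 1 to compound 3 (beyond the scatter) shows that the amine on that carbon cost only modestly. For the measured compounds named here, no measured step swaps an amine for an acetamido, so the direction is uncertain, but both known changes at this position lowered the number. A moderate drop is therefore expected for compound 4, of about a number 12 percentage points lower from compound 3 to compound 4 (beyond the scatter), with a wide range.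

Compound 4 is estimated to give 38% in this assay, expected to fall between 12% and 64%.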

Compound 4, a percentage reported as inhibition, at one concentration (the size of the read-out at that concentration, not a potency): 40%
The estimate for compound 4 lay 2 percentage points below the measured number, within the range that was stated.
By their numbers in this assay, from the lowest: compound 2; then compounds 4 and 3 (each within the scatter of the next); then compound 1.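

Turning the amine on the carbon attached to the shared core into an acetamide makes no difference beyond the usual scatter in this assay (a number 10 percentage points lower from compound 3 to compound 4 (within the scatter)), so this position takes the larger 1-acetamido-5-aminopentyl group, with its added carbonyl, about as well as 1,5-diaminopentyl. The free amine on that carbon is therefore not needed to keep the level of inhibition seen with compound 3. The other two steps place the new group in the wider set: it stands well clear of the carboxy-bearing side chain (a number 35 percentage points higher from compound 2 to compound 4 (beyond the scatter)), yet does not match the unbranched 3-aminopropyl chain (a number 27 percentage points lower from compound 1 to compound 4 (beyond the scatter)), and nothing shown here gives a reason for either difference.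

As far as these compounds go, it remains open whether a bulkier group on that nitrogen, such as a benzoyl or a methanesulfonyl, would be taken up as well, and whether the amine at the end of the chain in compound 4 matters, which a hydroxyl in its place would test. The opposite configuration at this carbon is also an open question, and a reading at a single concentration does not give a potency.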